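The source may hold more compounds than are shown below. What is called first, only, known or untested is meant among the compounds shown, and "the series" means these compounds.

Measured in a functional assay on SW480 cells (Homo sapiens) for antiproliferative activity, read by MTT assay, with a stated time of 48 h; a higher number here means a weaker inhibitor, a lower number a stronger inhibitor:
- Compound 1 `CC(CCO)n1cnc2c(Cl)nc(F)nc21`: 16800 nM
- Compound 2 `CC(CCO)n1cnc2c(Cl)ncnc21`: > 50000 nM, a limit

For the measured compounds named here, compound 1 holds the only actual number in this small set, so it has no measured value to be ranked against. Compound 2 is reported only as a limit, > 50000 nM.

The open question concerns compound 3 `CCC(CCO)n1cnc2c(Cl)nc(F)nc21`, which departs from compound 1 by methyl in place of hydrogen on a saturated chain carbon, two bonds along the chain from an aromatic nitrogen. This is methyl in place of hydrogen on a saturated chain carbon, two bonds along the chain from an aromatic nitrogen, and it can equally be read as methyl to ethyl.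

Going by the values given here, the one measured step, an at least 2.9-fold higher number from compound 1 to compound 2 (0.47 log units; beyond the scatter), is hydrogen in place of fluoro on an aromatic carbon. It therefore concerns a different place and a different kind of change, and it offers no direct guide to the size of this one. Compound 3 keeps the fluoro of compound 1, whose value of 16800 nM is the natural anchor, so no shift beyond the scatter is expected in this assay. The expected change is a 1.1-fold lower number from compound 1 to compound 3 (0.05 log units; within the scatter). For compound 3 the estimated value is 15000 nM, with an expected range from 6000 nM to 40000 nM.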

Compound 3, half-maximal inhibitory concentration: 19800 nM
Compound 3: the middle estimate sits 1.3-fold (0.12 log units) below what was measured; low and high end bracket the measured number.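

In this assay, methyl in place of hydrogen on a saturated chain carbon, two bonds along the chain from an aromatic nitrogen, gives a 1.2-fold higher number from compound 1 to compound 3 (0.07 log units; within the scatter), so this change leaves the antiproliferative reading of the fluoro compounds unchanged within the usual scatter. For the compounds shown here, the only earlier step, an at least 2.9-fold higher number from compound 1 to compound 2 (0.47 log units; beyond the scatter), concerned the fluoro on an aromatic carbon and said nothing about the chain, so this is the first reading at this position, and methyl to ethyl is a change it tolerates in this assay. Nothing given here offers a cause for this lack of effect.

This single step does not show how far that tolerance extends, and a longer chain or a phenyl group at this position, or an amine or a carboxylic acid in place of the hydroxyl, could behave differently. As far as these compounds go, whether methyl in place of hydrogen at this position would also leave the reading unchanged without the fluoro remains open as well.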